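A few compounds are considered here, and "the series" means these few. Any claim that something is new, unique, unknown or untested is made for them only; others in the source may bear on it.

Compound 1 `O=C(NCc1ccc(S(=O)(=O)c2ccccc2)cc1)c1cc2ncccc2s1` stands at the weaker end of the two numbers in hand: in an assay for inhibition of Nicotinamide phosphoribosyltransferase (Homo sapiens), read by mass spectrometry, with stated times of 15 min and 30 min (on this read-out lower numbers stand for stronger inhibition and higher numbers for weaker inhibition), compound 1 gives 400 nM, whereas compound 2 `O=C(NCc1ccc(S(=O)(=O)c2cccc(C(F)(F)F)c2)cc1)c1cc2cnccc2[nH]1` gives 8 nM in this assay, a gap that lies well beyond the scatter. Compound 2 differs from compound 1 in more than one place, so the two values show only that much and no single step can be read from them.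

Compound 3 `O=C(NCc1ccc(S(=O)(=O)c2ccccc2)cc1)c1ccc2nncn2c1` keeps the whole left-hand part of compound 1 and changes only the ring system on the amide: a group of 9 heavy atoms (6 carbon, 3 nitrogen; one five-membered aromatic ring with 3 hetero atoms, one six-membered aromatic ring with 1 hetero atom) in place of a group of 9 heavy atoms (7 carbon, 1 nitrogen, 1 sulfur; one five-membered aromatic ring with 1 hetero atom, one six-membered aromatic ring with 1 hetero atom), on a carbonyl carbon. For the measured compounds named here, no measured pair shows this exchange, so nothing in hand fixes its size or direction. He expects the step from compound 1 to compound 3 in this assay, a 1.3-fold lower number from compound 1 to compound 3 (0.12 log units; within the scatter), to stay within the usual scatter, with no clear change in either direction. His estimate for compound 3 in this assay is therefore 300 nM, expected to fall between 60 nM and 1500 nM.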

Compound 3, half-maximal inhibitory concentration: 370 nM
Estimate against measurement, compound 3: 1.2-fold (0.09 log units) below, within the range that was stated.
By their numbers in this assay, from the lowest: compound 2; then compounds 3 and 1 (each within the scatter of the next).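

In this assay, for the compounds shown here, the exchange on the carbonyl carbon is a 1.1-fold lower number from compound 1 to compound 3 (0.03 log units; within the scatter), the first step that can be read in one place, and it shows no difference between the two ring systems. At this place, then, the group with three nitrogens and three hydrogen-bond acceptors and the sulfur-bearing group with two acceptors read alike when the rest of compound 1 is kept. No evidence in hand bears on why these two groups read alike.

The compounds shown do not tell whether the value of compound 2, 8 nM, comes from its ring system on the amide, its trifluoromethyl group or both. Going by these compounds, how a simple amine or a carboxylic acid would read on this carbonyl carbon also remains open.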